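The source may hold more compounds than are shown below. What is called first, only, known or untested is meant among the compounds shown, and "the series" means these compounds.

Of the compounds shown here, two have been measured in a functional assay on the whole organism (stomach) for inhibition, with Canis familiaris (Canis lupus familiaris) as the target, at a dose of 40 mg/kg by the oral route; on this read-out lower numbers stand for a weaker effect and higher numbers for a stronger effect at the one dose given. Compound 1 `CCCN(CCC)CCN(C(=O)N(C)C)c1cc(C)cc(C)n1` gives 93% in this assay, whereas compound 2 `Cc1cc(C)nc(N(CCCN(C(C)C)C(C)C)C(=O)N(C)C)c1` gives 35% in this assay. Among the measured compounds shown here, compound 2 therefore stands lowest of the two numbers; its nearest neighbour is compound 1, and the only measured step, a number 58 percentage points lower from compound 1 to compound 2 (beyond the scatter), combines a change of the amine with a lengthening of the chain.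

Compound 3 `Cc1cc(C)nc(N(CCCCN(C(C)C)C(C)C)C(=O)N(C)C)c1` has not yet been measured in this assay. It differs from compound 2 in one place: (diisopropylamino)methyl in place of diisopropylamino on a saturated chain carbon, three bonds along the chain from an amide-type nitrogen. For the measured compounds named here, the only step that bears on this change is a number 58 percentage points lower from compound 1 to compound 2 (beyond the scatter), and it bears on it only in part, since it also exchanged the amine; no measured pair isolates a lengthening of the chain alone. On that slender basis, a step that is small or within the scatter, leaning downward rather than upward, is expected for compound 3, which amounts to an estimated change of a number 5 percentage points lower from compound 2 to compound 3 (within the scatter) in this assay.

In sum, compound 3 is estimated to give 30% in this assay, with the likely range running from 10% to 55%.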

Compound 3, a percentage reported as inhibition, in the whole organism at one dose (the size of the read-out at that dose, not a potency): 3%
Compound 3: middle estimate off by 27 percentage points, on the high side; the whole stated range lies above it.
By their numbers in this assay, from the lowest: compound 3; then compound 2; then compound 1.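

Among the compounds shown here, the step of a number 32 percentage points lower from compound 2 to compound 3 (beyond the scatter) in this assay is the first measured change that leaves the diisopropylamino group itself in the molecule, with (diisopropylamino)methyl simply entering in its place on a saturated chain carbon, three bonds along the chain from an amide-type nitrogen. It shows that this lengthening of the chain alone, which the earlier step of a number 58 percentage points lower from compound 1 to compound 2 (beyond the scatter) could not separate from an exchange of the amine, is enough to lower the read-out beyond the scatter, and that compound 2 did not already mark the floor of the effect at this dose. No measurement shown here accounts for this drop.

The compounds shown leave open whether the same lengthening would lower the read-out with dipropylamino as the amine, so how much of the first step belongs to the amine and how much to the chain remains unsettled. They also leave open how a cyclic amine such as piperidine or pyrrolidine would fare at the end of either chain, and how a chain longer still would behave.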